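The source may report more compounds than this note shows. Statements on the series, on what has been measured and on what is new or still open speak of the compounds shown alone.

Working notes on the series.

Compound 1 `O=C(Nc1ccccc1C(=O)O)N[C@H]1CC[C@@H](Oc2ccc(F)cc2)CC1` carries a carboxylic acid on the aryl urea. In a functional assay on CRL2813 cells (Homo sapiens) for cytotoxicity, read by sulforhodamine B assay, with a stated time of 5 days (a lower number here means a stronger inhibitor, a higher number a weaker inhibitor), compound 1 gives only a limit, > 20000 nM, and no number. Compound 2 `CSc1ccccc1NC(=O)N[C@H]1CC[C@H](Oc2ccc(F)cc2)CC1` is the same core with methylsulfanyl in place of the acid. In this assay compound 2 likewise returns only a limit, > 20000 nM, with no number behind it. Where compound 2 stands is therefore fixed only at one end: both values shown in this assay sit at the same limit, as the line the limit of > 20000 nM in this assay, at which 2 of the 2 values shown sit, records, and nothing separates the two compounds on the numbers.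

Compound 3 `O=C(Nc1ccccc1Br)N[C@H]1CC[C@H](Oc2ccc(F)cc2)CC1` is the next analogue, differing from compound 2 in one place: bromo in place of methylsulfanyl on an aromatic carbon, ortho to a large group. Among the compounds with values here, no step between measured compounds is available to size this change. With two of two values at the limit, the expectation is no movement beyond the scatter, and the step from compound 2 to compound 3 is estimated at a step that the limit leaves unreadable from compound 2 to compound 3. For compound 3 in this assay the estimate is 25000 nM, in a range from 8000 nM to 80000 nM, with the most likely outcome being another limit rather than a number.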

Compound 3, half-maximal inhibitory concentration: 7700 nM
Estimate against measurement, compound 3: 3.2-fold (0.51 log units) above; measured number outside the range, below it.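

A number now stands in this assay where the series had shown only limits, and the exchange of methylsulfanyl for bromo on an aromatic carbon, ortho to a large group, gives an at least 2.5-fold lower number from compound 2 to compound 3 (0.41 log units; beyond the scatter). The exchange is small by count, with methylsulfanyl leaving with its 2 heavy atoms and 1 hydrogen-bond acceptor and bromo entering with 1 heavy atom and no hydrogen-bond acceptor, while the rest of the molecule stays the same, so this place on the aromatic ring is shown to be one where a single group can move the read-out. The step is a bound rather than a size, since one end of it is not a number: the limit of > 20000 nM in this assay, at which 2 of the 3 values shown sit.

On these data alone, whether the lower number belongs to bromo in particular, or would also appear with chloro, methyl or methoxy on the same aromatic carbon, stays open. Also open, as far as these compounds go, is whether a nitrile or an amine at this place would give a number at all in this assay, and how far such a group would fall from compound 3.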